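A few compounds are considered here, and "the series" means these few. Any claim that something is new, unique, unknown or untested is made for them only; others in the source may bear on it.

Of the compounds shown here, three have been measured in an ADME assay on Vero cells (Chlorocebus sabaeus) for cytotoxicity, read by CellTiter-Glo, with a stated time of 72 h; a higher number here means that more compound is tolerated, a lower number that less compound is tolerated. Compound 1 `[O-][n+]1nc(NC2CCC2)[n+]([O-])c2ccc(F)cc21` gives 1.6 ug/mL in this assay, and compound 2 `[O-][n+]1nc(NC2CCCC2)[n+]([O-])c2ccc(F)cc21` gives 2.3 ug/mL. Compound 2 differs from compound 1 by cyclopentyl in place of cyclobutyl on a nitrogen on an aromatic ring, a change that made a step of a 1.4-fold higher number from compound 1 to compound 2 (0.16 log units; within the scatter). Compound 3 `Cc1cccc2c1[n+]([O-])c(NC1CCC1)n[n+]2[O-]` carries a different core; how the two cores differ is not broken down here. In this assay compound 3 gives 22 ug/mL, the highest of the three numbers, beyond the scatter from both compound 1 and compound 2. Compound 4 `Cc1cccc2c1[n+]([O-])c(NC1CCCC1)n[n+]2[O-]` has not yet been measured. It differs from compound 3 by cyclopentyl in place of cyclobutyl on a nitrogen on an aromatic ring, the same change, at the same place, as that between compound 1 and compound 2. The step in this assay is expected to be small, a 1.3-fold higher number from compound 3 to compound 4 (0.10 log units; within the scatter), because the earlier step of a 1.4-fold higher number from compound 1 to compound 2 (0.16 log units; within the scatter) lay within the scatter. Compound 4 is therefore estimated at 28 ug/mL, with a likely range from 12 ug/mL to 60 ug/mL.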

Compound 4, half-maximal cytotoxic concentration: 3.7 ug/mL
Compound 4: middle estimate off by 7.6-fold (0.88 log units), on the high side; the measured number lies below the stated range.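

In this assay, cyclopentyl in place of cyclobutyl on a nitrogen on an aromatic ring gave a 5.9-fold lower number from compound 3 to compound 4 (0.77 log units; beyond the scatter). Within the data shown here, the change did not carry over from one core to the other, so the step read on the core of compound 1 was no guide to the step on the core of compound 3: the same change on two cores in this assay, a 1.4-fold higher number (0.16 log units; within the scatter) from compound 1 to compound 2 and a 5.9-fold lower number (0.77 log units; beyond the scatter) from compound 3 to compound 4, 8.5-fold (0.93 log units) apart, beyond the scatter of two such steps. This rests on one pair on each core, and it shows neither why the two cores part nor whether the same would hold for another change or a third core.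

The compounds shown leave open how a cyclohexyl or an isopropyl group on that nitrogen would behave on either core. They also leave open what an amine on the cyclopentyl ring would do to the number.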